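The source may report more compounds than this note shows. Statements on the series, on what has been measured and on what is new or still open speak of the compounds shown alone.

Measured in an ADME assay on L02 cells (Homo sapiens) for cytotoxicity, read by MTT assay, with a stated time of 24 h; on this read-out higher numbers stand for weaker inhibition and lower numbers for stronger inhibition:
- Compound 1 `CN1C/C(=C\c2ccncc2)C(=O)/C(=C/c2ccc(C#N)cc2)C1`: 14000 nM
- Compound 2 `O=C1/C(=C/c2cccnc2)CNC/C1=C\c1ccccc1F`: 15900 nM
- Compound 3 `Cc1ccc(S(=O)(=O)N2C/C(=C\c3cccnc3)C(=O)/C(=C/c3ccccc3F)C2)cc1`: 14900 nM

In this assay, compound 3 gives 14900 nM, within the scatter of both other compounds, so the three cannot be told apart. Compound 4 `O=C1/C(=C/c2cccnc2)CN(S(=O)(=O)c2ccc(F)cc2)C/C1=C\c1ccccc1F` differs from compound 3 by fluoro in place of methyl on an aromatic carbon, para to a large group. Going by the values given here, no measured step makes this exchange. The nearest evidence is a 1.1-fold lower number from compound 2 to compound 3 (0.03 log units; within the scatter), where adding the whole (4-methylphenyl)sulfonyl group left the value within the scatter. A change beyond the scatter is therefore not expected. The expected step is a 1.1-fold lower number from compound 3 to compound 4 (0.03 log units; within the scatter). For compound 4 the estimated value is 14000 nM, with an expected range of 7500 nM to 26000 nM.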

Compound 4, half-maximal inhibitory concentration: 15600 nM
Beside the measured number, compound 4's estimate is 1.1-fold (0.05 log units) below it, within the range that was stated.
By their numbers in this assay, from the lowest: compounds 1, 3, 4 and 2 (each within the scatter of the next).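

In this assay, fluoro in place of methyl on an aromatic carbon, para to a large group, gives a 1.0-fold higher number from compound 3 to compound 4 (0.02 log units; within the scatter) and so gives this position its first direct step, which lies within the scatter. The (4-fluorophenyl)sulfonyl group in place of the hydrogen on the ring amine nitrogen gives a 1.0-fold lower number from compound 2 to compound 4 (0.01 log units; within the scatter) and is also within the scatter. No available evidence bears on this result. From the compounds shown here alone, whether an amine or a carboxylic acid on this aromatic carbon would stay within the scatter remains open, as does the effect of a longer chain in place of the aryl group on the sulfonyl.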